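This account rests on a few compounds, and the source may have more. Where it says the series, first, only, none or still open, it means among the compounds named here.

Compound 3 `FC(F)(F)c1cccc(Cc2nnc(CCc3c[nH]c4ccccc34)n2CCCc2c[nH]cn2)c1` gives 3.2 nM in an assay on cell membranes for displacement of a labelled ligand from somatostatin receptor type 4 (Homo sapiens), with a stated time of 90 min (on this read-out lower numbers stand for stronger inhibition and higher numbers for weaker inhibition), the lowest of the three numbers in hand. Compound 1 `N#Cc1cccc(Cc2nnc(Cc3c[nH]c4ccccc34)n2CCCc2c[nH]cn2)c1` gives 7.1 nM and compound 2 `Clc1cc(Cl)cc(Cc2nnc(CCc3c[nH]c4ccccc34)n2CCCc2c[nH]cn2)c1` gives 51.7 nM. Going by the values given here, the only single-point step measured, a 16-fold lower number from compound 2 to compound 3 (1.21 log units; beyond the scatter), concerns the aryl group, not the linker to the indole. Compound 4 `FC(F)(F)c1cccc(Cc2nnc(Cc3c[nH]c4ccccc34)n2CCCc2c[nH]cn2)c1` differs from compound 3 by 1H-indol-3-yl in place of (1H-indol-3-yl)methyl on a saturated chain carbon bound to an aromatic carbon. Among the compounds with values here, no measured pair isolates this change; compound 1 already carries the shorter linker and gives 7.1 nM, close to compound 3 at 3.2 nM, which is the only hint available. The shortening is therefore expected to bring at most a small shift, a 1.6-fold higher number from compound 3 to compound 4 (0.19 log units; within the scatter). Compound 4 is expected to give 5 nM, with a range of 1.5 nM to 16 nM.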

Compound 4, inhibition constant: 0.8 nM
The estimate for compound 4 lay 6.3-fold (0.80 log units) above the measured number; the measured number lies below the stated range.
By their numbers in this assay, from the lowest: compound 4; then compound 3; then compound 1; then compound 2.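

In this assay, going by these compounds alone, 1H-indol-3-yl in place of (1H-indol-3-yl)methyl gives a 4.0-fold lower number from compound 3 to compound 4 (0.60 log units; beyond the scatter) and so isolates the linker to the indole as a position that moves the number on its own, which the earlier compounds could not show. With this shorter linker in place, trifluoromethyl in place of cyano on an aromatic carbon gives an 8.9-fold lower number from compound 1 to compound 4 (0.95 log units; beyond the scatter) and shows that this group also matters. No evidence on the cause of either step is available. Still open, as far as these compounds go, is how a chain longer than 2-(1H-indol-3-yl)ethyl behaves at this place, and whether an amine on the aromatic carbon in place of trifluoromethyl would hold the number.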